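Methyl to Ethyl on the Saturated Carbon of Compound 1

The source may report more compounds than this note shows. Statements on the series, on what has been measured and on what is new or still open speak of the compounds shown alone.

Measured so far:
compound 1 `Cc1cc(=O)[nH]c(-n2nc3c(c2C)CCCC3)n1` — 1100 nM
compound 2 `CCc1cc(CC)n(-c2nc(C)cc(=O)[nH]2)n1` — 3800 nM

Of the compounds shown here, two have been tested in an assay on HEK293T cells for inhibition, read by scintillation counting, with stated times of 5 min and 15 min, at pH 5.5; a lower number here means a stronger inhibitor, a higher number a weaker inhibitor. Compound 1 gives 1100 nM in this assay, the lower of the two numbers, so it is the stronger inhibitor of the pair. Compound 2 gives 3800 nM, and the gap between these two values lies beyond the usual scatter. The two structures differ in more than one place, so nothing more than the values themselves can be read from this pair.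

Compound 3 `CCc1c2c(nn1-c1nc(C)cc(=O)[nH]1)CCCC2` is not yet measured. It differs from compound 1 in a single place: methyl in place of hydrogen on a saturated chain carbon bound to an aromatic carbon. For the measured compounds named here, with no measured pair showing this kind of change, only a small step is expected, and the expected step of a 1.4-fold higher number from compound 1 to compound 3 (0.13 log units; within the scatter) may well stay within the scatter in this assay. Compound 3 is estimated at 1500 nM, with a range from 500 nM to 4500 nM.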

Compound 3, half-maximal inhibitory concentration: 2260 nM
Estimate against measurement, compound 3: 1.5-fold (0.18 log units) below, and the stated range covers the measured number.
By their numbers in this assay, from the lowest: compound 1; then compounds 3 and 2 (each within the scatter of the next).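

For the compounds shown here, replacing hydrogen with methyl on a saturated chain carbon bound to an aromatic carbon, which turns the methyl of compound 1 into the ethyl of compound 3, is the first change in a single place here, and in this assay it gives a 2.1-fold higher number from compound 1 to compound 3 (0.31 log units; beyond the scatter) for this one pair. The step is modest but lies beyond the scatter, so this position does respond to a single added carbon, and the response is towards a weaker inhibitor. Nothing available explains why the number rises.

As far as these compounds go, it remains open whether a longer chain such as propyl would raise the number further. A single step also cannot show how a hydroxyl group or an amine on this carbon would compare with the methyl of compound 1.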